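Compound 3 to compound 4 on a shared core

The source may hold more compounds than are shown below. What is called first, only, known or untested is meant among the compounds shown, and "the series" means these compounds.

In a physicochemical assay for solubility, using the shake flask method, with a stated time of 12 h (a higher number here means a more soluble compound, a lower number a less soluble compound), compound 1 `O=C(/C=C/c1cccc(O)c1O)CC(=O)/C=C/c1cccc(O)c1O` gives 5300 nM and compound 2 `O=C(/C=C/c1cccc(O)c1)CC(=O)/C=C/c1cccc(O)c1O` gives 8200 nM as its reading. Compound 3 `O=C(/C=C/c1ccc(O)cc1)CC(=O)/C=C/c1cccc(O)c1O` gives 4800 nM and lies within the scatter of both others. Compound 4 `O=C(/C=C/c1cc(O)ccc1O)CC(=O)/C=C/c1cccc(O)c1O` differs from compound 3 by 2,5-dihydroxyphenyl in place of 4-hydroxyphenyl on a double-bonded chain carbon bound to a double-bonded chain carbon with 2,5-dihydroxyphenyl in place of 4-hydroxyphenyl on a double-bonded chain carbon bound to a double-bonded chain carbon. Three measured steps alter the hydroxy groups at this same place: a 1.5-fold higher number from compound 1 to compound 2 (0.19 log units; within the scatter) and a 1.1-fold lower number from compound 1 to compound 3 (0.04 log units; within the scatter) and a 1.7-fold lower number from compound 2 to compound 3 (0.23 log units; within the scatter) all stay within the scatter. No step beyond the scatter is therefore expected, and the expected step is a 1.1-fold higher number from compound 3 to compound 4 (0.06 log units; within the scatter) as a result. Compound 4 is estimated at 5500 nM with an expected range from 2800 nM to 10000 nM around it.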

Compound 4, solubility: 100000 nM
Compound 4: middle estimate off by 18-fold (1.26 log units), on the low side; measured number above the stated range.
By their numbers in this assay, from the lowest: compounds 3, 1 and 2 (each within the scatter of the next); then compound 4.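

In this assay, going by these compounds alone, the 2,5-dihydroxyphenyl group is the first change at this place to go beyond the scatter (with a 21-fold higher number from compound 3 to compound 4 (1.32 log units; beyond the scatter) and a 12-fold higher number from compound 2 to compound 4 (1.09 log units; beyond the scatter)). The comparison with the other dihydroxyphenyl group gives a large step as well (with a 19-fold higher number from compound 1 to compound 4 (1.28 log units; beyond the scatter)), so at this place the arrangement of the hydroxy groups matters, not merely their presence.

Going by these compounds, whether a methoxy group or an amine in place of either hydroxy group would keep this high reading stays open. Nothing given here explains the jump.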